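The source may hold more compounds than are shown below. What is called first, only, known or untested is meant among the compounds shown, and "the series" means these compounds.

In a functional assay on A549 cells (Homo sapiens) for cytotoxicity (on this read-out higher numbers stand for an effect only at larger amounts of compound and lower numbers for an effect already at smaller amounts), compound 1 (`CCC1=C(OC)C(CC)(CC)C(=O)C(C(=O)/C=C/c2ccccc2)=C1O`) gives 3.4 ug/mL and compound 2 (`CCC1=C(OC)C(CC)(CC)C(=O)C(C(=O)/C=C/c2ccc(C)cc2)=C1O`) gives 4.6 ug/mL, so these two stand within the scatter of each other. Compound 3 (`CCC1=C(OC)C(CC)(CC)C(=O)C(C(=O)/C=C/c2ccc(CC)cc2)=C1O`) differs from compound 2 by methyl in place of hydrogen on a saturated chain carbon bound to an aromatic carbon, which turns 4-methylphenyl into 4-ethylphenyl. Within the data shown here, the only measured step that bears on this is a 1.4-fold higher number from compound 1 to compound 2 (0.13 log units; within the scatter), also a methyl in place of hydrogen, though on an aromatic carbon, and it stays within the scatter. The expected result in this assay is therefore no shift beyond the scatter, with an estimated 1.0-fold higher number from compound 2 to compound 3 (0.02 log units; within the scatter). The value expected for compound 3 is 4.8 ug/mL, with an estimated range from 2.4 ug/mL to 9.5 ug/mL.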

Compound 3, concentration for half-maximal effect: 3.8 ug/mL
Estimate against measurement, compound 3: 1.3-fold (0.10 log units) above; measured number inside the range.
By their numbers in this assay, from the lowest: compounds 1, 3 and 2 (each within the scatter of the next).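

With 4-ethylphenyl in place of 4-methylphenyl, methyl on a saturated chain carbon bound to an aromatic carbon gives a 1.2-fold lower number from compound 2 to compound 3 (0.08 log units; within the scatter) in this assay, so the change on this chain carbon stays within the scatter, as the earlier change on the aromatic carbon did. Taken as a whole, the change from hydrogen to ethyl gives a 1.1-fold higher number from compound 1 to compound 3 (0.05 log units; within the scatter), so neither methyl nor ethyl here separates from hydrogen beyond the scatter. No evidence is available on what lies behind these numbers. The compounds shown leave open whether a longer chain, an amine or a carboxylic acid at this position would give a number beyond the scatter.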